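The source may report more compounds than this note shows. Statements on the series, on what has been measured and on what is new or still open speak of the compounds shown alone.

Among the measured compounds shown here, compound 3 `O=C(CCCc1ccncc1)N1CCN(c2ccc(Cl)cc2Cl)CC1` gives 5300 nM in a functional assay on HEK293 cells for positive allosteric modulation of metabotropic glutamate receptor 5 (Homo sapiens), read by FLIPR and calcium flux (a higher number here means that more compound is needed for the effect, a lower number that less compound is needed), the highest of the three numbers so far; compound 1 `O=C(COCc1cnccn1)N1CCN(c2ccc(Cl)cc2Cl)CC1` gives 5200 nM, a pair that shows no change (a 1.0-fold higher number from compound 1 to compound 3 (0.01 log units; within the scatter)), while compound 2 `O=C(COCc1cscn1)N1CCN(c2ccc(Cl)cc2Cl)CC1` gives 290 nM, the furthest off (an 18-fold higher number from compound 2 to compound 3 (1.26 log units; beyond the scatter)). For the measured compounds named here, the only large step in the set is an 18-fold lower number from compound 1 to compound 2 (1.25 log units; beyond the scatter). Compound 4 `O=C(CSCc1ccccc1)N1CCN(c2ccc(Cl)cc2Cl)CC1` differs from compound 3 by benzylsulfanyl in place of 2-(pyridin-4-yl)ethyl on a saturated chain carbon bound to a carbonyl carbon. Going by the values given here, the two steps at this carbon, an 18-fold higher number from compound 2 to compound 3 (1.26 log units; beyond the scatter) and a 1.0-fold higher number from compound 1 to compound 3 (0.01 log units; within the scatter), show that this position tolerates a large swing or none at all; no step involves benzylsulfanyl, so the direction is unsettled. A moderate lowering is expected, a 2.7-fold lower number from compound 3 to compound 4 (0.42 log units; beyond the scatter). For compound 4 the estimated value is 2000 nM, with a range of 400 nM to 9000 nM.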

Compound 4, half-maximal effective concentration: 7100 nM
Beside the measured number, compound 4's estimate is 3.6-fold (0.55 log units) below it; the range from low to high includes it.
By their numbers in this assay, from the lowest: compound 2; then compounds 1, 3 and 4 (each within the scatter of the next).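

Benzylsulfanyl on this saturated chain carbon bound to a carbonyl carbon reads like 2-(pyridin-4-yl)ethyl and (pyrazin-2-yl)methoxy in this assay, with a 1.3-fold higher number from compound 3 to compound 4 (0.13 log units; within the scatter) and a 1.4-fold higher number from compound 1 to compound 4 (0.14 log units; within the scatter). Its ring of carbon only, with sulfur in the chain, does not reach compound 2, as (1,3-thiazol-4-yl)methoxy still stands apart, with a 24-fold higher number from compound 2 to compound 4 (1.39 log units; beyond the scatter). No measurement at hand explains the size of these steps.

Open, going by these compounds, is whether the ring or the linking atom carries the gap to compound 2, which a (1,3-thiazol-4-yl)methylsulfanyl group would separate. On these data alone, how an amine in the chain would read also remains open.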